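Adding fluoro to the second ring of compound 2

This account rests on a few compounds, and the source may have more. Where it says the series, first, only, none or still open, it means among the compounds named here.

Compound 1 `COc1cc(CCc2ccncc2)cc(OC)c1O` gives > 25000 nM as a limit of the assay
Compound 2 `COc1cc(CCc2ccccc2)cc(OC)c1O` gives 10900 nM as an exact number
Compound 3 `COc1cc(CCc2cccc(F)c2)cc(OC)c1O` gives 2240 nM as an exact number

In a functional assay on A549 cells (Homo sapiens) for antiproliferative activity, read by MTT assay, with a stated time of 72 h (a higher number here means a weaker inhibitor, a lower number a stronger inhibitor), compound 2 has 10900 nM as the higher of the two exact numbers, and compound 3 is its nearest neighbour. Compound 1 shows only a limit (> 25000 nM).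

Compound 4 `COc1cc(CCc2ccccc2F)cc(OC)c1O` carries one change (fluoro in place of hydrogen on an aromatic carbon), namely fluoro in place of hydrogen on an aromatic carbon, ortho to a large group. The step of a 4.9-fold lower number from compound 2 to compound 3 (0.69 log units; beyond the scatter) came from the same swap at a different place on the ring, so it is the closest guide. The step of an at least 2.2-fold lower number from compound 1 to compound 2 (0.36 log units; beyond the scatter) came from phenyl in place of pyridin-4-yl, a different change, and guides little. A move to a lower number is therefore expected, estimated as a 2.2-fold lower number from compound 2 to compound 4 (0.34 log units; beyond the scatter) and probably smaller than the closest guide. Compound 4 is estimated at 5000 nM (expected range 2000 nM to 12000 nM).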

Compound 4, half-maximal inhibitory concentration: > 25000 nM
Compound 4 gave a limit, no number; the forecaster's own chance of this, stated with the estimate: 3%; at least 5.0-fold (0.69 log units) between middle value and limit.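

Fluoro in place of hydrogen, ortho to a large group, gives an at least 2.2-fold higher number from compound 2 to compound 4 (0.36 log units; beyond the scatter) in this assay, whereas the same swap at another place on the ring gives a 4.9-fold lower number from compound 2 to compound 3 (0.69 log units; beyond the scatter). Among these compounds, the place of the fluoro therefore decides the direction of the step, not only its size. Compound 4 shows a limit, not a number, so the full size of its step stays unknown: the limit of > 25000 nM in this assay, at which 2 of the 4 values shown sit.

On these data alone, whether chloro or an amine at this same place would also give a higher number remains open.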